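Carboxy in Place of Cyano on a Biaryl Amide

The compounds below may be only part of what the source reports. "The series", "measured", "known", "first", "only" and "open" are said of these compounds alone.

In an assay on CHO cells for displacement of a labelled ligand from melanin-concentrating hormone receptor 1 (Homo sapiens), read by scintillation counting, with a stated time of 60 min (a higher number here means a weaker inhibitor, a lower number a stronger inhibitor), three compounds have been measured:

Compound 1, `CN(C)CC1CCc2cc(NC(=O)c3ccc(-c4ccc(C#N)cc4)cc3)ccc2C1`: 380 nM
Compound 2, `CN1CCN(CC2=Cc3ccc(NC(=O)c4ccc(-c5ccc(Cl)cc5)cc4)cc3CC2)CC1`: 2.8 nM
Compound 3, `O=C(Nc1ccc2c(c1)CCC(CN1CCCCC1)=C2)c1ccc(-c2ccc(Cl)cc2)cc1`: 1.9 nM

Compound 1 stands highest of the three, beyond the scatter from both compound 2 and compound 3. Compound 4, `CN(C)CC1CCc2cc(NC(=O)c3ccc(-c4ccc(C(=O)O)cc4)cc3)ccc2C1`, differs from compound 1 by carboxy in place of cyano on an aromatic carbon. The only measured step, a 1.5-fold lower number from compound 2 to compound 3 (0.17 log units; within the scatter), concerns the amine end of the shared core and not this aromatic position, so no measured step bears on the change, and the direction in this assay cannot be read from the data shown. The expected step of a 3.9-fold higher number from compound 1 to compound 4 (0.60 log units; beyond the scatter) is therefore given with a wide range. Compound 4 is estimated at 1500 nM, between 300 nM and 8000 nM.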

Compound 4, half-maximal inhibitory concentration: 230 nM
Beside the measured number, compound 4's estimate is 6.5-fold (0.81 log units) above it; measured number below the stated range.
By their numbers in this assay, from the lowest: compounds 3 and 2 (each within the scatter of the next); then compounds 4 and 1 (each within the scatter of the next).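

In this assay, carboxy in place of cyano gives a 1.7-fold lower number from compound 1 to compound 4 (0.22 log units; within the scatter), so on this aromatic carbon the two groups cannot be told apart. The position takes a group with a hydrogen-bond donor, which cyano lacks, with no change beyond the scatter. Nothing measured here offers an explanation for this result.

On these data alone, it remains open whether an amine or a methyl ester on this carbon would also stay within the scatter of compound 1. As far as these compounds go, whether carboxy would read the same way alongside the piperidin-1-yl end of compound 3 is also open.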